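Swapping pyrrolidin-1-yl for methylamino in compound 1

The source may report more compounds than this note shows. Statements on the series, on what has been measured and on what is new or still open speak of the compounds shown alone.

- compound 1 `O=C(/C=C/CNCCOc1ccc(Oc2c(-c3ccc(F)cc3)sc3cc(O)ccc23)cc1)N1CCCC1`: 7610 nM
- compound 2 `C=C(C)C(=O)NCCOc1ccc(Oc2c(-c3ccc(F)cc3)sc3cc(O)ccc23)cc1`: > 25000 nM (a limit)

Among the compounds with values here, in a functional assay on MCF7 cells (Homo sapiens) for antiproliferative activity, read by CCK-8 assay, with a stated time of 48 h (on this read-out higher numbers stand for weaker inhibition and lower numbers for stronger inhibition), compound 1 gives 7610 nM, the only exact number so far. Compound 2 reports only a limit, > 25000 nM. Within the data shown here, the one measured step, an at least 3.2-fold higher number from compound 1 to compound 2 (0.51 log units; beyond the scatter), replaces the whole 3-((pyrrolidin-1-yl)carbonyl)prop-2-en-1-yl group. Compound 3 `CNC(=O)/C=C/CNCCOc1ccc(Oc2c(-c3ccc(F)cc3)sc3cc(O)ccc23)cc1` changes far less, with methylamino in place of pyrrolidin-1-yl on a carbonyl carbon. A step as large as that one is therefore not expected. The expected change in this assay is a 1.3-fold higher number from compound 1 to compound 3 (0.12 log units; within the scatter), slightly towards weaker inhibition and not beyond the scatter. For compound 3 the estimate is 10000 nM, with an expected range of 3500 nM to 25000 nM.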

Compound 3, half-maximal inhibitory concentration: 16100 nM
Estimate against measurement, compound 3: 1.6-fold (0.21 log units) below; the range from low to high includes it.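

In this assay, changing only the group on the carbonyl carbon, with methylamino in place of pyrrolidin-1-yl, gives a 2.1-fold higher number from compound 1 to compound 3 (0.33 log units; beyond the scatter). This modest step shows that this end of the chain counts on its own, although one change both removes the pyrrolidin-1-yl ring and adds a hydrogen-bond donor. The other new step is an at least 1.5-fold lower number from compound 2 to compound 3 (0.19 log units; that floor lies within the scatter). That step gives only a floor, because compound 2 gives only a limit: the limit of > 25000 nM in this assay, at which 1 of the 3 values shown sits.

Which of those two differences matters remains open. Dimethylamino, with no ring and no amide hydrogen, would help separate them.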